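A few compounds are considered here, and "the series" means these few. Any claim that something is new, unique, unknown or untested is made for them only; others in the source may bear on it.

Working notes, series in an assay on cells for agonist activity at D(4) dopamine receptor (Homo sapiens), read by luminescence and beta-arrestin recruitment, with a stated time of 90 min; on this read-out higher numbers stand for larger maximal responses and lower numbers for smaller maximal responses. Three measured entries stand here. Compound 1 `CCc1cccc(NC(=O)CN2CCN(c3ccccn3)CC2)c1` gives 26.2%. Compound 2 `O=C(CN1CCN(c2ccccn2)CC1)Nc1cccnc1` gives 19%. Compound 3 `Cc1cccc(NC(=O)CCN2CCC(c3ccccn3)CC2)c1` is reported as "not active" (no number reported). Going by the values given here, the single one-place step among them is a number 7.2 percentage points lower from compound 1 to compound 2 (within the scatter), pyridin-3-yl in place of 3-ethylphenyl on the amide-type nitrogen. Compound 2 thus stands lowest of the two numbers, with compound 1 the nearest and within the scatter of it; compound 3 carries no number and differs from both in more than one place, so nothing is drawn from it.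

Compound 4 `O=C(CN1CCN(c2ccc(Cl)cn2)CC1)Nc1cccnc1` is to be measured in this assay. Its change from compound 2 is chloro in place of hydrogen on an aromatic carbon. Among the compounds with values here, no measured step touches that ring: the one known step, a number 7.2 percentage points lower from compound 1 to compound 2 (within the scatter), concerns the amide side and lies within the scatter, while the ring that here receives the chloro is unchanged between compounds 1 and 2. Within the data shown here, with no step to lean on, the expectation is that compound 2's value carries over with no move beyond the scatter, and no change at the digits printed from compound 2 to compound 4 (within the scatter) is the estimated change. Compound 4 is therefore expected to give 19%, with a range from 8% to 32%.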

Compound 4, largest response reached (Emax), in percent of the reference or control that the assay uses: "not active" (no number reported)
Compound 4: no number reported; there is nothing to compare the estimate with.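

Going by these compounds alone, compound 4 is reported as "not active" without a number, so no step from compound 2 to compound 4 can be read. No evidence on hand bears on this result. The compounds shown leave open what size of change, if any, 5-chloropyridin-2-yl in place of pyridin-2-yl brings to the maximal response.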